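Amino in place of hydrogen on compound 3

The source may report more compounds than this note shows. Statements on the series, on what has been measured and on what is new or still open speak of the compounds shown alone.

Values in an in vitro ADME assay on microsomes (Homo sapiens) for metabolic stability (on this read-out lower numbers stand for a shorter-lived compound and higher numbers for a longer-lived compound), so far:
- compound 1 `Cc1c2c(n3c1CCCNC[C@H](C)Nc1cc-3ccc1C(N)=O)CC(C)(C)CC2=O` gives 0.167 h
- compound 2 `Cc1c2c(n3c1CCN(C(=O)[C@H](C)N)CC[C@H](C)Nc1cc-3ccc1C(N)=O)CC(C)(C)CC2=O` gives 0.433 h
- compound 3 `CC(=O)N1CCc2c(C)c3c(n2-c2ccc(C(N)=O)c(c2)N[C@@H](C)[C@H](C)C1)CC(C)(C)CC3=O` gives 0.05 h

Compound 3 (0.05 h) is the lowest of the three in this assay and lies beyond the scatter from both compound 1 and compound 2. Compound 4 `Cc1c2c(n3c1CCN(C(=O)CN)C[C@@H](C)[C@H](C)Nc1cc-3ccc1C(N)=O)CC(C)(C)CC2=O` differs from compound 3 in one place, by amino in place of hydrogen on a saturated chain carbon bound to a carbonyl carbon.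

For the measured compounds named here, no measured pair shows this change on its own, so the expectation rests on thin ground. Going by the values given here, the only guide is compound 2 (0.433 h), which also has amino on a saturated chain carbon bound to a carbonyl carbon, although its chain differs from that of compound 3. On that basis a rise in this assay beyond the scatter is expected rather than no change. The expected size of the rise is a 4.0-fold higher number from compound 3 to compound 4 (0.60 log units; beyond the scatter) and it stays short of the full gap to compound 2. Compound 4 is estimated at 0.2 h with an expected range of 0.07 h to 0.6 h for repeat measurements.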

Compound 4, half-life: > 0.5 h
Compound 4: no number, only a limit; the forecaster's own chance of this, stated with the estimate: 3%; middle value at least 2.5-fold (0.39 log units) from the limit.
By their numbers in this assay, from the lowest: compound 3; then compound 1; then compound 2. At a limit, above all of these: compound 4.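

Compound 4 is reported in this assay only as a limit of the assay, not as a number: the limit of > 0.5 h in this assay, at which 1 of the 4 values shown sits.

This gives the series its first single-place reading at a saturated chain carbon bound to a carbonyl carbon, namely an at least 10-fold higher number from compound 3 to compound 4 (1.00 log units; beyond the scatter). Before this, no pair of compounds differed in one place, so the presence of amino in compound 2 could not be separated from its other differences in the chain. The change from acetyl to (aminomethyl)carbonyl, taken on its own, is now shown to move this read-out beyond the usual scatter on the chain of compound 3.

As far as these compounds go, this remains a single pair, so it is open whether the same change gives a step of similar direction on the chain of compound 1 or on other chains. From the compounds shown here alone, it is also open whether the step depends on the amino group itself, which a hydroxyl or dimethylamino group, or an amine carried on a longer chain, on a saturated chain carbon bound to a carbonyl carbon would help to settle.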